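The source may hold more compounds than are shown below. What is called first, only, known or untested is meant among the compounds shown, and "the series" means these compounds.

Compound 2 `O=C1COCCN1c1ccc(/N=C\c2cn(C(=O)c3ccccc3)c3ccccc23)cc1` and compound 1 `Cc1ccc(S(=O)(=O)n2cc(/C=N\c3ccc(N4CCOCC4=O)cc3)c3ccccc32)cc1` share a core and differ only in the group on the aromatic nitrogen. Going by the values given here, in an ADME assay on BV-2 cells (Mus musculus) for cytotoxicity, read by MTT assay, with a stated time of 48 h, tested at 100 uM (a higher number here means a weaker effect of the compound at the concentration tested, a lower number a stronger effect), compound 1 gives 57.4%, and compound 2 gives 52.9%; these two values lie within the scatter of each other, so compound 2 stands on a par with its only neighbour. Among the compounds with values here, the one measured step in this assay, a number 4.5 percentage points lower from compound 1 to compound 2 (within the scatter), was made at the same nitrogen. Compound 3 `O=C1COCCN1c1ccc(/N=C\c2cn(Cc3ccc(F)cc3)c3ccccc23)cc1` changes that position again: 4-fluorobenzyl in place of benzoyl on an aromatic nitrogen. The benzoyl step bears on it by place but not in kind, since the carbonyl leaves and no acceptor enters, and it gave no step beyond the scatter. No shift beyond the scatter is therefore expected for compound 3, and a number 2.9 percentage points lower from compound 2 to compound 3 (within the scatter) is the estimated step. Compound 3 is expected to give 50% in this assay, within a range from 30% to 72%.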

Compound 3, a percentage reported as activity, at one concentration (the size of the read-out at that concentration, not a potency): 55.5%
Compound 3: the middle estimate sits 5.5 percentage points below what was measured; the measured number falls inside the stated range.
By their numbers in this assay, from the lowest: compounds 2, 3 and 1 (each within the scatter of the next).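

In this assay, 4-fluorobenzyl in place of benzoyl on the aromatic nitrogen gives a number 2.6 percentage points higher from compound 2 to compound 3 (within the scatter) and 4-fluorobenzyl in place of (4-methylphenyl)sulfonyl gives a number 1.9 percentage points lower from compound 1 to compound 3 (within the scatter) at the same place. The earlier step changed one group bearing a hydrogen-bond acceptor for another, whereas here the benzoyl carbonyl leaves, no acceptor enters, and the reading still stays within the scatter, so neither of these changes at this nitrogen separates the compounds. Nothing available explains this result.

On these data alone, whether a group of another kind on this nitrogen, such as a carboxylic acid or a longer chain ending in an amine, would move the reading beyond the scatter stays open. The compounds shown also say nothing about changes elsewhere on the shared core.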